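This account rests on a few compounds, and the source may have more. Where it says the series, first, only, none or still open, it means among the compounds named here.

In a toxicity assay on MRC5 cells (Homo sapiens) for inhibition, read by MTT assay, with a stated time of 72 h (on this read-out higher numbers stand for weaker inhibition and lower numbers for stronger inhibition), compound 1 (`CCCCCCCCCCCCSCCc1ccc(OCc2ccc(OC)cc2)c(OCc2ccc(OC)cc2)c1`) gives > 50000 nM, which is a limit of the assay and not a number. Among the measured compounds shown here, compound 2 (`CCCCCC(=O)OCCc1ccc(O)cc1`) gives 166000 nM, the only actual number available, so its standing cannot yet be judged against a measured neighbour. Compound 3 (`CCCCCCCCCCCC(=O)OCCc1ccc(O)cc1`) carries hexyl in place of hydrogen on a saturated chain carbon, five bonds along the chain from a carbonyl carbon. For the measured compounds named here, no measured step shows what this change does in this assay, so only a modest shift towards stronger inhibition is expected. The expected step is a 2.1-fold lower number from compound 2 to compound 3 (0.32 log units; beyond the scatter). For compound 3 the estimated value is 80000 nM, with an expected range of 25000 nM to 250000 nM.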

Compound 3, half-maximal inhibitory concentration: 67200 nM
For compound 3 the middle estimate is 1.2-fold (0.08 log units) above the measured one; low and high end bracket the measured number.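

In this assay, among the compounds shown here, this is the first measured effect at this position: hexyl in place of hydrogen on a saturated chain carbon, five bonds along the chain from a carbonyl carbon, gives a 2.5-fold lower number from compound 2 to compound 3 (0.39 log units; beyond the scatter). The step is modest but beyond the scatter, so added chain length at this position does shift the read-out towards stronger inhibition. Compound 1 has only a limit, which gives no number to compare: the limit of > 50000 nM in this assay, at which 1 of the 3 values shown sits.

Going by these compounds, whether a longer chain would extend this shift remains open. So does what an amine or a carboxylic acid at this position would do.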